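A few compounds are considered here, and "the series" means these few. Any claim that something is new, unique, unknown or untested is made for them only; others in the source may bear on it.

Compound 1 `CC1(C)N=C(N)N=C(N)N1c1ccccc1F` gives 4.39 in an assay on isolated protein for inhibition of Dihydrofolate reductase (Mus musculus), at pH 7.20; on this read-out lower numbers stand for lower potency and higher numbers for higher potency (the scale is a negative logarithm). Compound 2 `CC1(C)N=C(N)N=C(N)N1c1ccccc1Cl` gives 4.72 in this assay. Among the measured compounds shown here, the one measured step, a number 0.33 log units higher from compound 1 to compound 2 (beyond the scatter), is the only comparison available. For the measured compounds named here, compound 2 therefore stands highest of the two numbers known in this assay, with compound 1 the nearest and lower by that same step.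

Compound 3 `CC1(C)N=C(N)N=C(N)N1c1ccccc1I` is the next member. Relative to compound 2 the change is iodo in place of chloro on an aromatic carbon, at the same place on the six-membered aromatic ring of carbon only, ortho to a large group. The step that bears on it is a number 0.33 log units higher from compound 1 to compound 2 (beyond the scatter), where a larger halogen replaced a smaller one at this place and a modest rise beyond the scatter followed. Continuing in that direction, a modest rise in this assay is expected, estimated as a number 0.18 log units higher from compound 2 to compound 3 (within the scatter). For compound 3 the expected value in this assay is 4.9, with a range from 4.5 to 5.3.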

Compound 3, logarithm of the reciprocal of the active concentration, log(1/C): 2.49
Beside the measured number, compound 3's estimate is 2.41 log units above it, and the stated range ends above it.
By their numbers in this assay, from the lowest: compound 3; then compound 1; then compound 2.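

At this place on the aromatic ring, the halogens give no steady trend: iodo in place of chloro brings a number 2.23 log units lower from compound 2 to compound 3 (beyond the scatter) and iodo in place of fluoro brings a number 1.90 log units lower from compound 1 to compound 3 (beyond the scatter) in this assay and so leaves compound 3 lowest of the three. The modest rise with chloro in place of fluoro therefore does not carry on to iodo, and the exchange of one halogen atom for another, with no donor, acceptor or charge counted on either side, can produce a large step here. Nothing available bears on the reason for this fall.

Going by these compounds, whether bromo at this place would stay close to chloro or fall towards iodo remains open. So does the response to a group without halogen, such as methyl or methoxy.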